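The source may report more compounds than this note shows. Statements on the series, on what has been measured and on what is new or still open speak of the compounds shown alone.

Measured in an ADME assay on Vero cells (Chlorocebus sabaeus) for cytotoxicity, read by sulforhodamine B assay, with a stated time of 72 h; on this read-out lower numbers stand for stronger inhibition and higher numbers for weaker inhibition:

Compound 1 `CN1Cc2ccc(OCc3ccccc3)cc2[C@@H](O)C1`: > 100000 nM
Compound 2 `CN1Cc2ccc(O)cc2[C@@H](OCc2ccccc2)C1`: > 50000 nM
Compound 3 `CN1Cc2c(O)cccc2[C@@H](O)C1`: > 100000 nM

None of these three entries is an exact number, since each is a limit of the assay. They gather at two limits: the limit of > 100000 nM in this assay, at which 2 of the 3 values shown sit, and (the limit of > 50000 nM in this assay, at which 1 of the 3 values shown sits). Compound 3 stands at > 100000 nM, which is a limit.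

Compound 4 `COc1cccc2c1CN(C)C[C@@H]2O` differs from compound 3 in one place: methyl in place of hydrogen on an oxygen on an aromatic ring. In words, this is methyl in place of hydrogen on an oxygen on an aromatic ring, or hydroxy to methoxy.

Within the data shown here, no two measured compounds differ in just one place, so no measured step shows what this change does. With every reading so far at a limit, I expect no step beyond the usual scatter in this assay, and most likely another limit. The expected change, a number no higher from compound 3 to compound 4 (the limit leaves the size open), is only an estimate. For compound 4 the estimated value is 100000 nM, with an expected range of 40000 nM to 200000 nM.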

Compound 4, half-maximal inhibitory concentration: > 100000 nM
Compound 4 was reported as a limit; the forecaster's own chance of this, stated with the estimate: 90%; the middle value sits exactly at the limit.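

Compound 3 and compound 4 are both reported only as limits in this assay, so the step between them, hydroxy to methoxy, cannot be read. The compounds shown leave open what exact value either compound has, and so whether this change affects the read-out at all.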